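Removing the Phenyl Group from Compound 1

This account rests on a few compounds, and the source may have more. Where it says the series, first, only, none or still open, it means among the compounds named here.

- Compound 1 `S=C(NNc1nncc2ccccc12)Nc1ccccc1`: 74 nM
- Compound 2 `COc1ccc(NC(=S)NNc2nncc3ccccc23)cc1`: 88 nM

In a functional assay on MDA-MB-435 cells (Homo sapiens) for antiproliferative activity, read by sulforhodamine B assay, with a stated time of 72 h (on this read-out higher numbers stand for weaker inhibition and lower numbers for stronger inhibition), compound 1 has the lowest number of the two, but only within the scatter: a 1.2-fold higher number from compound 1 to compound 2 (0.08 log units; within the scatter). Compound 3 `NC(=S)NNc1nncc2ccccc12` differs from compound 1 by hydrogen in place of phenyl on an amide-type nitrogen, which is hydrogen in place of phenyl on an amide-type nitrogen. Among the measured compounds shown here, the only measured step is that methoxy-for-hydrogen change, and it keeps the phenyl, so it offers little guidance on losing the whole group. A clear move toward weaker inhibition in this assay is expected, as an estimated 4.1-fold higher number from compound 1 to compound 3 (0.61 log units; beyond the scatter). For compound 3 the estimated value is 300 nM, with an expected range of 70 nM to 1500 nM.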

Compound 3, half-maximal inhibitory concentration: 52 nM
For compound 3 the middle estimate is 5.8-fold (0.76 log units) above the measured one; measured number below the stated range.
By their numbers in this assay, from the lowest: compounds 3, 1 and 2 (each within the scatter of the next).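

Hydrogen in place of phenyl on the amide-type nitrogen gives a 1.4-fold lower number from compound 1 to compound 3 (0.15 log units; within the scatter) in this assay, so inhibition at this level does not depend on the phenyl. Compound 2 kept that group and could not show this; compound 3 shows that the entire ring can leave this nitrogen. Nothing available explains why this place accepts the change.

Still open, on these data alone, is how this nitrogen responds to groups other than hydrogen and substituted or unsubstituted phenyl, such as a methyl, a longer chain or a chain ending in a carboxylic acid.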